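From vinyl to 2-methylprop-1-en-1-yl on the carbonyl carbon

This account rests on a few compounds, and the source may have more. Where it says the series, first, only, none or still open, it means among the compounds named here.

In a functional assay on A549 cells (Homo sapiens) for antiproliferative activity, read by MTT assay, with a stated time of 72 h (a lower number here means a stronger inhibitor, a higher number a weaker inhibitor), compound 3 `C=CC(=O)Nc1cccc(Oc2nc(Nc3ccc(OC)nc3)nc3c2CSCC3)c1` gives 14600 nM and lies within the scatter of compound 1 `COc1cccc(Nc2nc3c(c(Oc4cccc(NC(=O)C=C(C)C)c4)n2)CSCC3)c1` at 19800 nM while compound 2 `CC(C)=CC(=O)Nc1cccc(Oc2nc(Nc3cccc(C#N)c3)nc3c2CSCC3)c1` at 36900 nM stands beyond the scatter with the higher number. Compound 4 `COc1ccc(Nc2nc3c(c(Oc4cccc(NC(=O)C=C(C)C)c4)n2)CSCC3)cn1` differs from compound 3 by 2-methylprop-1-en-1-yl in place of vinyl on a carbonyl carbon with 2-methylprop-1-en-1-yl in place of vinyl on a carbonyl carbon. For the measured compounds named here, the only measured step of a 1.9-fold higher number from compound 1 to compound 2 (0.27 log units; within the scatter) is cyano in place of methoxy on an aromatic carbon, so it does not test this change and lies within the scatter. Compound 1 at 19800 nM already carries 2-methylprop-1-en-1-yl on that carbonyl carbon, yet lies within the scatter of compound 3, so this assay is expected to show no step beyond the scatter. The expected step of a 1.4-fold higher number from compound 3 to compound 4 (0.14 log units; within the scatter) stays within the scatter. For compound 4 the estimated value is 20000 nM with 9000 nM to 45000 nM as the expected range.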

Compound 4, half-maximal inhibitory concentration: 16800 nM
For compound 4 the middle estimate is 1.2-fold (0.08 log units) above the measured one; the measured number falls inside the stated range.
By their numbers in this assay, from the lowest: compounds 3, 4, 1 and 2 (each within the scatter of the next, the first and the last beyond it).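

In this assay the direct test of 2-methylprop-1-en-1-yl in place of vinyl on the carbonyl carbon gives a 1.2-fold higher number from compound 3 to compound 4 (0.06 log units; within the scatter) and so shows no effect that can be told from the scatter. For the compounds shown here, with that group held, 6-methoxypyridin-3-yl in place of 3-methoxyphenyl gives a 1.2-fold lower number from compound 1 to compound 4 (0.07 log units; within the scatter) while 6-methoxypyridin-3-yl in place of 3-cyanophenyl gives a 2.2-fold lower number from compound 2 to compound 4 (0.34 log units; beyond the scatter) and is the only one of these steps to pass the scatter. Nothing measured here accounts for these numbers. As far as these compounds go, whether the vinyl swap reads the same with 3-methoxyphenyl or 3-cyanophenyl on the nitrogen stays open. So does the effect of a dimethylamino group or a longer chain on that carbonyl carbon.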